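Tert-butyl on the fused ring: compound 3 to compound 4

The source may hold more compounds than are shown below. What is called first, only, known or untested is meant among the compounds shown, and "the series" means these compounds.

In a functional assay on the whole organism (strain Wistar) for inhibition, with Rattus norvegicus as the target, read by paw edema, with stated times of 30 min and 3 h, at a dose of 200 mg/kg by the oral route (on this read-out higher numbers stand for more inhibition at the one dose given (going by the name of the read-out) and lower numbers for less inhibition), compound 1 `N#Cc1ccc(-c2cc3c(n2-c2ccc(O)c(C(=O)O)c2)CCCC3)cc1` gives 0%, and compound 2 `O=C(O)c1cc(-n2c(-c3ccc([N+](=O)[O-])cc3)cc3c2CCCC3)ccc1O` gives 30%; the step is a number 30 percentage points higher from compound 1 to compound 2 (beyond the scatter). Compound 3 `O=C(O)c1cc(-n2c(-c3ccccc3)cc3ccccc32)ccc1O` is known only as a limit of the assay, >= 60%, which is the limit of >= 60% in this assay, at which 1 of the 3 values shown sits. Compound 4 `CC(C)(C)c1ccc2c(c1)cc(-c1ccccc1)n2-c1ccc(O)c(C(=O)O)c1` differs from compound 3 by tert-butyl in place of hydrogen on an aromatic carbon. Among the measured compounds shown here, no measured step touches this position; the single measured step concerns a different place in the molecule and offers no guide to the present change. With nothing to point elsewhere, no step beyond the scatter is expected, a number no higher from compound 3 to compound 4 (the limit leaves the size open). Compound 4 is therefore estimated to give 60%, within 35% to 80%, and a limit rather than a number may again be reported.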

Compound 4, a percentage reported as inhibition, in the whole organism at one dose (the size of the read-out at that dose, not a potency): 0%
The estimate for compound 4 lay 60 percentage points above the measured number, outside the stated range (below it).
By their numbers in this assay, from the lowest: compounds 1 and 4 (each within the scatter of the next); then compound 2. At a limit, above all of these: compound 3.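

In this assay, this carbon of the six-membered aromatic ring proves sensitive to substitution: tert-butyl in place of hydrogen gives a number at least 60 percentage points lower from compound 3 to compound 4 (beyond the scatter). Among the compounds shown here, the earlier step concerned a different place, so this is the first reading at this position, and here a single change removes the inhibition seen at the one dose given. The size of the step has only a lower bound, with compound 3 standing at a limit: the limit of >= 60% in this assay, at which 1 of the 4 values shown sits.

The compounds shown leave open whether a methyl group or a chlorine atom on the same carbon would retain the inhibition of compound 3.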